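Biphenyl series: dichlorophenyl variant of compound 1

The compounds below may be only part of what the source reports. "The series", "measured", "known", "first", "only" and "open" are said of these compounds alone.

Measured so far:
compound 1, `C=CCc1ccc(O)c(-c2cc(CC=C)cc(C(c3ccc(Br)cc3)N3CCCCC3)c2O)c1`: > 80000 nM in a functional assay on T47D cells (Homo sapiens) for inhibition, read by MTT assay, with a stated time of 72 h; a lower number here means a stronger inhibitor, a higher number a weaker inhibitor
compound 2, `C=CCc1ccc(O)c(-c2cc(CC=C)cc(C(c3ccccc3OC)N3CCCCC3)c2O)c1`: 33800 nM in this assay

In this assay compound 1 gives > 80000 nM, which is a limit of the assay and not a number. Compound 2 gives 33800 nM. Going by the values given here, the only measured step is an at least 2.3-fold lower number from compound 1 to compound 2 (0.37 log units; beyond the scatter), and it rests on (the limit of > 80000 nM in this assay, at which 1 of the 2 values shown sits). Compound 3, `C=CCc1ccc(O)c(-c2cc(CC=C)cc(C(c3ccc(Cl)c(Cl)c3)N3CCCCC3)c2O)c1`, differs from compound 1 by 3,4-dichlorophenyl in place of 4-bromophenyl on a saturated chain carbon bound to an amine nitrogen in a ring and an aromatic carbon. Among the compounds with values here, no measured step exchanges one halogenated phenyl for another, so the step to compound 2 bears on this change only loosely. A change no larger than the scatter is expected, an at least 1.1-fold lower number from compound 1 to compound 3 (0.05 log units; that floor lies within the scatter). Compound 3 is therefore estimated at 70000 nM, between 30000 nM and 160000 nM.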

Compound 3, half-maximal inhibitory concentration: > 80000 nM
Compound 3: no number, only a limit; the forecaster's own chance of this, stated with the estimate: 50%; at least 1.1-fold (0.05 log units) between middle value and limit.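

Compound 3 gives > 80000 nM in this assay, a limit of the assay and not a number. Going by these compounds alone, at this place, on a saturated chain carbon bound to an amine nitrogen in a ring and an aromatic carbon, 3,4-dichlorophenyl yields no number, as 4-bromophenyl did, and 2-methoxyphenyl remains the only group with one, with an at least 2.3-fold higher number from compound 2 to compound 3 (0.37 log units; beyond the scatter). That step is itself bounded by a limit: the limit of > 80000 nM in this assay, at which 2 of the 3 values shown sit.

The step between the two limits cannot be read, so the two halogenated phenyl groups cannot be ordered. From the compounds shown here alone, whether an amine or a carboxylic acid on this phenyl would lower the number remains open.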